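The source may report more compounds than this note shows. Statements on the series, on what has been measured and on what is new or still open speak of the compounds shown alone.

The series shares one core, carried in `CCC(CC)(c1ccc(OCC(=O)C(C)(C)CCc2ccccc2)c(C)c1)c1ccc(OC[C@@H](O)CO)c(C)c1` as compound 1, which in an assay on HL-60 cells for activation of vitamin D3 receptor (Homo sapiens) (a lower number here means that less compound is needed, a higher number that more compound is needed for the effect), gives 23000 nM. Compound 2, `CCC(CC)(c1ccc(OCC(=O)C(C)(C)Cc2ccc3ccccc3c2)c(C)c1)c1ccc(OC[C@@H](O)CO)c(C)c1`, reaches only the limit of this assay, > 30000 nM. Going by the values given here, the sole measured step, an at least 1.3-fold higher number from compound 1 to compound 2 (0.11 log units; that floor lies within the scatter), is the only direct comparison in hand, and it rests on (the limit of > 30000 nM in this assay, at which 1 of the 3 values shown sits). Compound 3, `CCC(CC)(c1ccc(OCC(O)C(C)(C)CCc2ccccc2)c(C)c1)c1ccc(OC[C@@H](O)CO)c(C)c1`, carries a hydroxyl where compound 1 has the carbonyl; in this assay compound 3 gives 7100 nM, the lowest of the two numbers shown, with compound 1 standing above it. Compound 4, `CCC(CC)(c1ccc(OCC(O)C(C)(C)CCCCc2ccccc2)c(C)c1)c1ccc(OC[C@@H](O)CO)c(C)c1`, is not yet measured. Its difference from compound 3 is phenethyl in place of phenyl on a saturated chain carbon, four bonds along the chain from an oxygen on a saturated carbon; cut one bond further out, the same change reads benzyl to 3-phenylpropyl or phenethyl to 4-phenylbutyl. Among the compounds with values here, no measured step lengthens this chain: the step from compound 1 to compound 2 swaps one aromatic group for another and ends at a limit, so it gives no size to carry over. The working expectation for compound 4 is therefore no step beyond the scatter, a 1.0-fold lower number from compound 3 to compound 4 (0.01 log units; within the scatter). Compound 4 is estimated in this assay at 7000 nM, within 2500 nM to 20000 nM.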

Compound 4, half-maximal effective concentration: > 30000 nM
Compound 4: no number, only a limit; the forecaster's own chance of this, stated with the estimate: 5%; middle value at least 4.2-fold (0.63 log units) from the limit.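

Phenethyl in place of phenyl on a saturated chain carbon, four bonds along the chain from an oxygen on a saturated carbon, is the first lengthening of this chain with a measured outcome in this assay, and it gives an at least 4.2-fold higher number from compound 3 to compound 4 (0.62 log units; beyond the scatter). The only earlier step, an at least 1.3-fold higher number from compound 1 to compound 2 (0.11 log units; that floor lies within the scatter), swapped one aromatic group for another and did not get beyond the scatter even at its floor, whereas this change does, so the length of this chain matters among the hydroxyl compounds shown. Compound 4 nevertheless carries a limit rather than a number, which makes the size of the step a floor only: the limit of > 30000 nM in this assay, at which 2 of the 4 values shown sit.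

The compounds shown leave open how the numbers run at the length in between, where a 3-phenylpropyl group would stand, and whether a shorter benzyl group on the same carbon would lower the number of compound 3. Also open, going by these compounds, is whether a carboxylic acid or an amine at the end of the longer chain would bring a number back within range of this assay, and whether the carbonyl form of compound 4 behaves alike.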